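Fluoro Added to a Pyridinyl-Aminopyrimidine Efficacy Series

The source may hold more compounds than are shown below. What is called first, only, known or untested is meant among the compounds shown, and "the series" means these compounds.

Compound 1 `CNc1nc(NCc2ccc(NC(C)=O)cc2)cc(-c2ccccn2)n1` and compound 2 `CNc1nc(NCc2ccc(NS(C)(=O)=O)cc2)cc(-c2ccccn2)n1` share a core and differ only in the group on the aniline nitrogen. In a functional assay on HEK293 cells for agonist activity at G-protein coupled receptor 39 (Homo sapiens), read by cAMP accumulation (on this read-out lower numbers stand for smaller maximal responses and higher numbers for larger maximal responses), compound 1 gives 48%, the lower of the two numbers, while compound 2 gives 55%; the step of a number 7 percentage points higher from compound 1 to compound 2 (within the scatter) says nothing about a difference between them. Compound 3 `CNc1nc(NCc2ccc(NC(C)=O)cc2F)cc(-c2ccccn2)n1` is compound 1 with fluoro in place of hydrogen on an aromatic carbon. For the measured compounds named here, no measured step bears on this change, and the one step known stays within the scatter, so no step beyond the scatter is expected: a number 2 percentage points higher from compound 1 to compound 3 (within the scatter). Compound 3 is therefore estimated at 50%, in the range 35% to 65%.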

Compound 3, largest response reached (reported as efficacy), in percent of the reference or control that the assay uses: 55%
Estimate against measurement, compound 3: 5 percentage points below, within the range that was stated.
By their numbers in this assay, from the lowest: compounds 1, 2 and 3 (each within the scatter of the next).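

In this assay, placing fluoro on the aromatic carbon ortho to a large group and meta to an acetamido group gives a number 7 percentage points higher from compound 1 to compound 3 (within the scatter) and so produces no readable change in maximal response. Earlier compounds differed only on the aniline nitrogen, whereas this change lies on the aromatic ring itself and also stays inside the scatter. Nothing available explains this outcome.

On these data alone, it remains open whether chloro, methyl or methoxy at this same carbon would move the response beyond the scatter. As far as these compounds go, whether fluoro would behave alike on compound 2 also remains open.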